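Ester Chain Variation and Cytotoxicity on a Shared Core

The source may hold more compounds than are shown below. What is called first, only, known or untested is meant among the compounds shown, and "the series" means these compounds.

Measured in a functional assay on HeLa cells (Homo sapiens) for cytotoxicity; on this read-out higher numbers stand for lower toxicity in this test and lower numbers for higher toxicity in this test:
Compound 1 `CCCCOC(=O)C(O)Cn1cnc2c(N)ncnc21`: 400 ug/mL
Compound 2 `CCCCCOC(=O)C(O)Cn1cnc2c(N)ncnc21`: > 400 ug/mL, which is a limit of the assay, not a number.

Compound 2 therefore stands at the top of the range seen, at the point described by the limit of > 400 ug/mL in this assay, at which 1 of the 2 values shown sits. Compound 3 `CC(C)(C)OC(=O)C(O)Cn1cnc2c(N)ncnc21` differs from compound 2 by tert-butyl in place of pentyl on an oxygen next to a carbonyl group. Among the compounds with values here, the single measured step, a number no lower from compound 1 to compound 2 (the limit leaves the size open), bears on it only loosely, since its size cannot be read. Within the data shown here, no measured step favours a shift in either direction beyond the scatter. The step from compound 2 to compound 3 is therefore expected to be a number no higher from compound 2 to compound 3 (the limit leaves the size open). Compound 3 is estimated at 400 ug/mL, between 200 ug/mL and 800 ug/mL.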

Compound 3, minimum cytotoxic concentration: > 400 ug/mL
Compound 3: a limit, no number; the forecaster's own chance of this, stated with the estimate: 55%; the middle value sits exactly at the limit.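

On an oxygen next to a carbonyl group, the chain need not be an unbroken pentyl to reach the upper end of the read-out, as tert-butyl in compound 3 gets there too: the limit of > 400 ug/mL in this assay, at which 2 of the 3 values shown sit. Replacing butyl with tert-butyl gives a number no lower from compound 1 to compound 3 (the limit leaves the size open). Within the data shown here, neither this step nor the one linking compound 2 with compound 3 can be read for size, so these groups cannot be ranked in this assay. As far as these compounds go, it remains open how a smaller chain such as methyl, a longer chain or a carboxylic acid in this place would read in this assay.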